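A few compounds are considered here, and "the series" means these few. Any claim that something is new, unique, unknown or untested is made for them only; others in the source may bear on it.

Of the compounds shown here, three built on one shared core have been tested in an in vitro assay on HEK385-7 cells for displacement of a labelled ligand from prostaglandin D2 receptor 2 (Homo sapiens); on this read-out higher numbers stand for weaker inhibition and lower numbers for stronger inhibition. Compound 1 `N#Cc1cc(-c2nc(C(c3ccc(F)cc3)c3ccc(F)cc3)sc2CC(=O)O)ccc1F` gives 57 nM, compound 2 `O=C(O)Cc1sc(C(c2ccc(F)cc2)c2ccc(F)cc2)nc1-c1ccnc(F)c1` gives 0.48 nM, and compound 3 `O=C(O)Cc1sc(C(c2ccc(F)cc2)c2ccc(F)cc2)nc1-c1ccoc1` gives 14 nM, the second highest of the three numbers. The measured steps leading to it are a 4.1-fold lower number from compound 1 to compound 3 (0.61 log units; beyond the scatter) and a 29-fold higher number from compound 2 to compound 3 (1.46 log units; beyond the scatter). Compound 4 `COc1cc(-c2nc(C(c3ccc(F)cc3)c3ccc(F)cc3)sc2CC(=O)O)ccn1` has not yet been measured and differs from compound 3 in one place: 2-methoxypyridin-4-yl in place of furan-3-yl on an aromatic carbon. The step of a 29-fold higher number from compound 2 to compound 3 (1.46 log units; beyond the scatter) bears most closely on this change, as compound 2 likewise carries a six-membered aromatic ring with 1 hetero atom. That step was large, so a large drop in this assay is expected, roughly reversing it; the expected step is a 12-fold lower number from compound 3 to compound 4 (1.07 log units; beyond the scatter). Compound 4 is estimated at 1.2 nM, in the range 0.3 nM to 5 nM.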

Compound 4, half-maximal inhibitory concentration: 29 nM
Compound 4: the middle estimate sits 24-fold (1.38 log units) below what was measured; measured number above the stated range.
By their numbers in this assay, from the lowest: compound 2; then compound 3; then compounds 4 and 1 (each within the scatter of the next).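

In this assay, a six-membered aromatic ring with 1 hetero atom at this position does not by itself give a low number, as 2-methoxypyridin-4-yl in place of furan-3-yl gives a 2.1-fold higher number from compound 3 to compound 4 (0.32 log units; beyond the scatter). The group on that ring counts for far more: methoxy in place of fluoro gives a 60-fold higher number from compound 2 to compound 4 (1.78 log units; beyond the scatter), while the comparison with 3-cyano-4-fluorophenyl gives a 2.0-fold lower number from compound 1 to compound 4 (0.29 log units; within the scatter). No measurement shown explains the gap between methoxy and fluoro. Open, as far as these compounds go, is whether chloro, methyl or an amine in place of fluoro would keep the number as low as in compound 2.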